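Demethylation step in a hydrazone series, cytotoxicity notes

The source may hold more compounds than are shown below. What is called first, only, known or untested is meant among the compounds shown, and "the series" means these compounds.

Measured compounds:
compound 1 `COc1cc(/C=N/NC(=O)OCc2ccccc2)cc(OC)c1O`, 69%
compound 2 `COc1cc(/C=N/Nc2nc3ccccc3s2)cc(OC)c1O`, 55%
compound 3 `COc1cc(/C=N/Nc2nc3ccccc3s2)cc(OC)c1OC`, 57%

All three were run in a functional assay on cells (Mus musculus) for cytotoxicity, read by MTT assay, with a stated time of 24 h, tested at 10 uM; a lower number here means a weaker effect, a higher number a stronger effect of the compound at the concentration tested. Compound 1 gives the highest number of the three; compound 3 and compound 2 each give a lower number, and in both cases the gap to compound 1 lies beyond the scatter. How the core of compound 1 differs from the core of compound 3 is not broken down here.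

Within the core of compound 3, one change has been measured: hydrogen in place of methyl on an oxygen on an aromatic ring. The step it made, a number 2 percentage points lower from compound 3 to compound 2 (within the scatter), lies within the scatter, so on that core the change is read as making no difference that the assay can resolve.

Compound 4 `COc1cc(/C=N/NC(=O)OCc2ccccc2)cc(O)c1O` is not yet measured. It stands to compound 1 as compound 2 stands to compound 3: hydrogen in place of methyl on an oxygen on an aromatic ring. The two place descriptions read the same word for word, so this is the same change, made on a different core. Going by the values given here, the only evidence for its size is the single step on the core of compound 3, where it was flat; whether it stays flat on the core of compound 1 is not known from these data.

On that basis compound 4 is expected to sit close to compound 1, with a step of about a number 2 percentage points lower from compound 1 to compound 4 (within the scatter) in this assay, a near-flat move that rests on a number 2 percentage points lower from compound 3 to compound 2 (within the scatter). The estimate for compound 4 is 67%, with a range from 55% to 78% to allow for the change of core, since the step was observed only once.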

Compound 4, a percentage reported as activity, at one concentration (the size of the read-out at that concentration, not a potency): 57%
Estimate against measurement, compound 4: 10 percentage points above; the measured number falls inside the stated range.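

In this assay, the change from methoxy to hydroxy on the core of compound 1 gives a number 12 percentage points lower from compound 1 to compound 4 (beyond the scatter), so on this core the step is one the assay can resolve, whereas the step on the core of compound 3 is not. This does not show that the change behaves differently on the two cores, and the result gives no ground for calling it core-dependent, since the two steps themselves cannot be told apart: the same change on two cores in this assay, a number 2 percentage points lower (within the scatter) from compound 3 to compound 2 and a number 12 percentage points lower (beyond the scatter) from compound 1 to compound 4, 10 percentage points apart, within the scatter of two such steps. Going by these compounds alone, what can be carried from one core to the other is therefore only a loose statement, that the change gives either no resolvable step or a modest lower number, and a single step on each core fixes neither a common size for the change nor a real difference between the cores.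

The compounds shown leave open whether the step would hold on a third core, and whether repeat measurements on these two cores would bring the two steps closer together or further apart. They also leave open what a different group in the same place, such as an ethoxy group or an amine, would do in this assay.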